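A Chloro for Methoxy Swap in a Level Series

The source may report more compounds than this note shows. Statements on the series, on what has been measured and on what is new or still open speak of the compounds shown alone.

In a functional assay on U-87MG ATCC cells for antiproliferative activity against U-87 MG (Homo sapiens), read by MTT assay, with a stated time of 48 h (a lower number here means a stronger inhibitor, a higher number a weaker inhibitor), three compounds have been measured and they lie close together. Compound 1 (`COc1ccc(-c2nc(C)c(C(=O)CSc3nc(-c4ccc(Cl)cc4)c(C#N)c(=O)[nH]3)s2)cc1`) gives 45900 nM, compound 2 (`Cc1nc(-c2ccc(Cl)cc2)sc1C(=O)CSc1nc(-c2cccc(Cl)c2)c(C#N)c(=O)[nH]1`) gives 40100 nM, and compound 3 (`COc1ccc(-c2nc(SCC(=O)c3sc(-c4ccc(Cl)cc4)nc3C)[nH]c(=O)c2C#N)cc1`) gives 35500 nM. Compound 3 therefore stands level with the other two, since its gaps to both fall within the scatter.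

Compound 4 (`Cc1nc(-c2ccc(Cl)cc2)sc1C(=O)CSc1nc(-c2ccc(Cl)cc2)c(C#N)c(=O)[nH]1`) has not yet been measured. It differs from compound 3 by chloro in place of methoxy on an aromatic carbon, para to a large group: chloro in place of methoxy on an aromatic carbon. The same change reads as 4-methoxyphenyl to 4-chlorophenyl.

Among the compounds with values here, the closest evidence is the one measured step at this aryl group, which put 4-methoxyphenyl in place of 3-chlorophenyl and came to a 1.1-fold lower number from compound 2 to compound 3 (0.05 log units; within the scatter). Compound 1 already carries a 4-chlorophenyl at that place and gives 45900 nM, but it also differs from compound 4 elsewhere. No change beyond the scatter is therefore expected in this assay, and the data favour no direction. The estimate amounts to an expected 1.1-fold higher number from compound 3 to compound 4 (0.03 log units; within the scatter). For compound 4, the expected value is 38000 nM, with an estimated range of 19000 nM to 75000 nM.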

Compound 4, half-maximal inhibitory concentration: 53000 nM
Compound 4: middle estimate off by 1.4-fold (0.14 log units), on the low side, within the range that was stated.
By their numbers in this assay, from the lowest: compounds 3, 2, 1 and 4 (each within the scatter of the next).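

Within the data shown here, compound 4 gives the first direct reading of chloro in place of methoxy at this position, where the earlier step had compared 4-methoxyphenyl only with 3-chlorophenyl: in this assay the exchange comes to a 1.5-fold higher number from compound 3 to compound 4 (0.17 log units; within the scatter) and so stays inside the scatter. Moving the chloro within the aryl group, read as 4-chlorophenyl in place of 3-chlorophenyl, gives a 1.3-fold higher number from compound 2 to compound 4 (0.12 log units; within the scatter) and likewise stays inside the scatter, so this position has now tolerated all three of these aryl groups without a change that can be told from noise. The same chloro for methoxy exchange at the other aryl group of the shared core gives a 1.2-fold higher number from compound 1 to compound 4 (0.06 log units; within the scatter) and again stays inside the scatter, so the exchange reads alike at both places in these compounds.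

Going by these compounds, every step here is small, and whether an amine or a carboxylic acid at this position would move the number beyond the scatter stays open. No measurement is at hand that could explain where these four compounds lie.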